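Two Hydrazones at the Assay Limit, and a Third

The source may hold more compounds than are shown below. What is called first, only, known or untested is meant among the compounds shown, and "the series" means these compounds.

Measured in a functional assay on A549 cells (Homo sapiens) for antiproliferative activity, read by MTT assay; on this read-out lower numbers stand for stronger inhibition and higher numbers for weaker inhibition:
Compound 1 `Cn1c(=O)c(=O)n(C2CCCC2)c2nc(N/N=C/c3ccccc3)ncc21`: > 100000 nM
Compound 2 `Cn1c(=O)c(=O)n(C2CCCC2)c2nc(N/N=C/c3ccc(O)cc3)ncc21`: > 100000 nM

Both entries are limits of the assay and not numbers. In this assay compound 2 stands at > 100000 nM, and nothing in the data places it more exactly. Compound 1 shows the same limit, > 100000 nM.

The next compound, compound 3 `Cc1cccc(/C=N/Nc2ncc3c(n2)n(C2CCCC2)c(=O)c(=O)n3C)c1`, changes one group of compound 2: 3-methylphenyl in place of 4-hydroxyphenyl on a carbon with a double bond to nitrogen. In words, this puts 3-methylphenyl in place of 4-hydroxyphenyl on a carbon with a double bond to nitrogen.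

For the measured compounds named here, only one measured step bears on this change, and it concerns the hydroxy group: a step that the two limits leave unreadable from compound 1 to compound 2. It offers no size to carry over, and the wider picture is the limit of > 100000 nM in this assay, at which 2 of the 2 values shown sit. Compound 3 is therefore expected to stay close to that limit in this assay, with no step beyond the scatter and no direction that can be argued from the data. The expected change is a number no higher from compound 2 to compound 3 (the limit leaves the size open). For compound 3 the estimate is 100000 nM, with an expected range from 30000 nM to 200000 nM.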

Compound 3, half-maximal inhibitory concentration: 34500 nM
For compound 3 the middle estimate is 2.9-fold (0.46 log units) above the measured one; the range from low to high includes it.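

Compound 3 is the first of the three hydrazones to give a real number in this assay, which shows that a change on this aromatic ring can bring the series inside the measurable range: the limit of > 100000 nM in this assay, at which 2 of the 3 values shown sit.

Replacing 4-hydroxyphenyl with 3-methylphenyl on the carbon with a double bond to nitrogen gives an at least 2.8-fold lower number from compound 2 to compound 3 (0.46 log units; beyond the scatter), while methyl in place of hydrogen on an aromatic carbon gives an at least 2.8-fold lower number from compound 1 to compound 3 (0.46 log units; beyond the scatter). The second step involves no hydroxy group, so the methyl group alone accompanies the gain over the unsubstituted phenyl ring, although both steps start from limits of the assay and not from numbers, which leaves their full size unknown.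

The compounds shown do not tell whether another group in place of this methyl, such as an amine, a carboxylic acid or a longer chain, would lower the number further or return it to the limit. They also leave open whether a hydroxy group and a methyl group on the same phenyl ring would give a number closer to that of compound 3 or to the limit shared by the other two compounds.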